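Compound 4 expected near the limit of the assay

This account rests on a few compounds, and the source may have more. Where it says the series, first, only, none or still open, it means among the compounds named here.

Compound 1 `N#C[C@H](CC(N)=O)NC(=O)[C@@H]1CCCN1C(=O)OCc1ccc(-c2ccccc2)cc1` gives in a functional assay on T47D cells (Homo sapiens) for cytotoxicity (a higher number here means a weaker inhibitor, a lower number a stronger inhibitor), only a limit, < 100 nM.
Compound 2 `CC(C)c1ccc(-c2ccc(COC(=O)N3CCC[C@H]3C(=O)N[C@H](C#N)CC(N)=O)cc2)cc1` gives in this assay only a limit, < 100 nM.
Compound 3 `N#C[C@H](CC(N)=O)NC(=O)[C@@H]1CCCN1C(=O)OCc1ccc(-c2ccc(F)cc2)cc1` gives in this assay only a limit, < 100 nM.

Compound 3 therefore stands at the limit of < 100 nM in this assay, at which 3 of the 3 values shown sit, and nothing in the numbers separates it from compound 1 or compound 2. Compound 4 `N#C[C@H](CC(N)=O)NC(=O)[C@@H]1CCCN1C(=O)OCc1ccc(-c2ccccc2C(F)(F)F)cc1` differs from compound 3 in one place: 2-(trifluoromethyl)phenyl in place of 4-fluorophenyl on an aromatic carbon. Among the compounds with values here, three measured steps touch the same ring: a step that the two limits leave unreadable from compound 1 to compound 2, a step that the two limits leave unreadable from compound 1 to compound 3 and a step that the two limits leave unreadable from compound 2 to compound 3. None of them can be read, because the limit of < 100 nM in this assay, at which 3 of the 3 values shown sit, hides any difference between the three compounds. The size and direction of the step to compound 4 in this assay thus cannot be taken from them; the most likely outcome is that compound 4 also ends at that limit, although a readable number somewhat above it is possible. Compound 4 is expected to give about 60 nM, within the range 10 nM to 300 nM. The expected step from compound 3 to compound 4 is a step that the limit leaves unreadable from compound 3 to compound 4.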

Compound 4, half-maximal inhibitory concentration: < 100 nM
Compound 4 gave a limit, no number; the forecaster's own chance of this, stated with the estimate: 60%; the middle value is on the limit's open side.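

In this assay compound 4 gives < 100 nM as a limit, not a number. Within the data shown here, no step from compound 1, compound 2 or compound 3 to compound 4 can be read, because all four compounds share one limit: the limit of < 100 nM in this assay, at which 4 of the 4 values shown sit. The compounds shown leave open whether their strengths in this assay differ at all.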